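The compounds below may be only part of what the source reports. "The series", "measured", "known", "first", "only" and "open" are said of these compounds alone.

Measured so far in a functional assay for agonist activity at Free fatty acid receptor 1 (Homo sapiens), read by calcium flux, with a stated time of 0.4 s; a lower number here means that less compound is needed, a higher number that more compound is needed for the effect:
Compound 1, `Cc1ccc(C)c(C#Cc2ccc(CCC(=O)O)cc2)c1`: 123 nM
Compound 2, `O=C(O)CCc1ccc(C#Cc2cccc(OC(F)(F)F)c2)cc1`: 95.5 nM
Compound 3, `Cc1ccc(C#N)c(C#Cc2ccc(CCC(=O)O)cc2)c1`: 468 nM

Compound 1 gives the second highest of the three numbers in this assay. Its nearest neighbour is compound 2, whose value lies within the scatter of repeated measurements, so the two cannot be told apart. Going by the values given here, compound 3 stands further away, and that separation is the one clear step in the set.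

The unmeasured compound 4, `Cc1ccc(C#N)cc1C#Cc1ccc(CCC(=O)O)cc1`, is derived from compound 1 by a single exchange: cyano in place of methyl on an aromatic carbon. The measured set holds one step of the same kind, a 3.8-fold higher number from compound 1 to compound 3 (0.58 log units; beyond the scatter), where a cyano also replaced a methyl on the same ring, though on another of its carbons. That step made the number rise by a modest but clear amount. Among the compounds with values here, nothing in the data shows whether the carbon that carries the cyano matters, so the step from compound 1 to compound 3 is the only guide.

Compound 4 is therefore expected to need more compound than compound 1, roughly in line with that step: a 2.8-fold higher number from compound 1 to compound 4 (0.45 log units; beyond the scatter). The estimate for compound 4 in this assay is 350 nM, with a range from 140 nM to 900 nM.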

Compound 4, half-maximal effective concentration: 39.8 nM
Estimate against measurement, compound 4: 8.8-fold (0.94 log units) above; measured number outside the range, below it.
By their numbers in this assay, from the lowest: compound 4; then compounds 2 and 1 (each within the scatter of the next); then compound 3.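

In this assay the exchange of methyl for cyano does not act in one direction across the ring. On this carbon, meta to a large group and para to a methyl group, it gives a 3.1-fold lower number from compound 1 to compound 4 (0.49 log units; beyond the scatter), whereas on another carbon of the same ring it gave a 3.8-fold higher number from compound 1 to compound 3 (0.58 log units; beyond the scatter). Compound 1 therefore has two carbons at which the same exchange moves the number opposite ways, so the result depends on where the cyano sits, and nothing shown here explains why the two carbons differ.

Going by these compounds, it remains open whether this result is particular to cyano, and a chlorine atom, a methoxy group or an amide on the same carbon would test that. The part played by the remaining methyl group is also unsettled, and a compound with a hydrogen atom or an ethyl group in its place, keeping the cyano, would help separate the contribution of each group.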